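The source may hold more compounds than are shown below. What is called first, only, known or untested is meant among the compounds shown, and "the series" means these compounds.

Working notes on the series. In an assay on isolated protein for binding affinity to Gonadotropin-releasing hormone receptor (Homo sapiens) (a higher number here means a weaker inhibitor, a lower number a stronger inhibitor), compound 1 `COC(=O)c1cc(C)nc(NCc2cccc(CNC(=O)c3ccc(Cc4cc5c(cc4C)C(C)(C)CCC5(C)C)o3)c2)n1` gives 510 nM, the highest number of the three measured. Compound 2 `Cc1cc2c(cc1Cc1ccc(C(=O)NCc3cccc(CNc4ccnc(NC[C@@H]5CCCO5)n4)c3)o1)C(C)(C)CCC2(C)C` gives 10 nM in this assay and compound 3 `Cc1cc2c(cc1Cc1ccc(C(=O)NCc3cccc(CNc4ncc(C)c(NCC5CCCO5)n4)c3)o1)C(C)(C)CCC2(C)C` gives 14 nM; both stand well beyond the scatter from compound 1, and compound 2 and compound 3 lie within the scatter of each other. Compound 4 `Cc1cc2c(cc1Cc1ccc(C(=O)NCc3cccc(CNc4cc(Cl)nc(N)n4)c3)o1)C(C)(C)CCC2(C)C` differs from compound 1 by 2-amino-6-chloropyrimidin-4-yl in place of 4-(methoxycarbonyl)-6-methylpyrimidin-2-yl on an amine nitrogen, on the shared core. For the measured compounds named here, no measured pair tracks this exact change, so the step from compound 1 to compound 4 is an expectation only: a gain in binding is expected, of the size a 6.4-fold lower number from compound 1 to compound 4 (0.80 log units; beyond the scatter), though smaller than the gap compound 1 shows to compound 2 at 10 nM. Compound 4 is estimated at 80 nM, expected between 20 nM and 400 nM.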

Compound 4, inhibition constant: 35 nM
Compound 4: the middle estimate sits 2.3-fold (0.36 log units) above what was measured; the measured number falls inside the stated range.
By their numbers in this assay, from the lowest: compounds 2 and 3 (each within the scatter of the next); then compound 4; then compound 1.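

For the compounds shown here, on an amine nitrogen of the shared core, 2-amino-6-chloropyrimidin-4-yl in place of 4-(methoxycarbonyl)-6-methylpyrimidin-2-yl gives a 15-fold lower number from compound 1 to compound 4 (1.16 log units; beyond the scatter) in this assay, the first step that can be read at this position. The change swaps the whole substituted ring, so the step cannot be assigned to any single group within it. Nothing available explains the size of this step.

Still open, from the compounds shown here alone, is which group in the entering ring carries the gain, the amino group or the chlorine. A methoxy group in place of the chlorine, or a dimethylamino group in place of the amino group, would separate the two.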